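Side-chain trimming in a benzamide-bearing purine series

A few compounds are considered here, and "the series" means these few. Any claim that something is new, unique, unknown or untested is made for them only; others in the source may bear on it.

Of the compounds shown here, three have been measured in a functional assay on HepG2 cells (Homo sapiens) for antiproliferative activity, read by CCK-8 assay, with a stated time of 72 h, tested at 2 uM; on this read-out lower numbers stand for a weaker effect and higher numbers for a stronger effect at the one concentration tested. Compound 1 `COC(CCn1cnc2c(NCc3ccc(C(=O)Nc4ccccc4N)cc3)nc(Cl)nc21)OC` gives 8.52% and stands lowest of the three. Compound 2 `CCCCn1cnc2c(Nc3cccc(Cl)c3)nc(NCOCc3ccc(/C=C/C(=O)Nc4ccccc4N)cc3)nc21` gives 20.5%, a number higher than that of compound 1 by a gap beyond the scatter. Compound 3 `Nc1ccccc1NC(=O)c1ccc(Cn2cnc3c(Nc4ccccc4)nc(Cl)nc32)cc1` gives 49.6%, the highest of the three and far beyond the scatter from compound 1. No pair among these three differs in one place only, so no single step can be read from them.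

Compound 4 `CCCCn1cnc2c(NCc3ccc(C(=O)Nc4ccccc4N)cc3)nc(Cl)nc21` is the unmeasured neighbour of compound 1. It differs by ethyl in place of dimethoxymethyl on a saturated chain carbon, two bonds along the chain from an aromatic nitrogen. Cut one bond further out, the same change reads as 3,3-dimethoxypropyl to butyl on the saturated chain. Compound 2, which also carries a butyl chain but differs elsewhere, offers only loose guidance.

The step from compound 1 to compound 4 is expected to be small and upward, a number 11.5 percentage points higher from compound 1 to compound 4 (beyond the scatter), near the edge of the scatter. For compound 4 the estimate in this assay is 20%, within 5% to 40%.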

Compound 4, a percentage reported as inhibition, at one concentration (the size of the read-out at that concentration, not a potency): 6.8%
The estimate for compound 4 lay 13.2 percentage points above the measured number; the range from low to high includes it.
By their numbers in this assay, from the lowest: compounds 4 and 1 (each within the scatter of the next); then compound 2; then compound 3.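

In this assay, this position on the saturated chain now has its first one-place comparison, and replacing dimethoxymethyl with ethyl gives a number 1.7 percentage points lower from compound 1 to compound 4 (within the scatter), so the read-out does not separate the 3,3-dimethoxypropyl and butyl chains on this core at the one concentration tested. Loss of both oxygens of the dimethoxymethyl group therefore produces no resolved change in this pair, and both chains leave the read-out in the same range. No supporting data offer an explanation for this result.

As far as these compounds go, it remains open whether a chain ending in an amine or a carboxylic acid, or a longer chain such as hexyl, would separate from these two compounds. From the compounds shown here alone, it is also open whether the same chain change would remain unresolved on a different core or at another concentration.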